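This account rests on a few compounds, and the source may have more. Where it says the series, first, only, none or still open, it means among the compounds named here.

Compound 1 `CCCCCCCCNc1nccnc1C(=O)NCc1ccccc1` gives 100000 nM.
Compound 2 `CCCCNc1nccnc1C(=O)NCc1ccccc1` gives only a limit of the assay, > 100000 nM.
Compound 3 `CCCCNc1cncc(C(=O)NCc2ccccc2)n1` gives 100000 nM.

All three were measured in an ADME assay on MDCK cells (Canis lupus familiaris) for cytotoxicity, read by microscopy, with a stated time of 6 days; on this read-out lower numbers stand for higher toxicity in this test and higher numbers for lower toxicity in this test. Compound 4 `CCCCCCCCNc1cncc(C(=O)NCc2ccccc2)n1` has not yet been measured in this assay. It differs from compound 3 by butyl in place of hydrogen on a saturated chain carbon, four bonds along the chain from a nitrogen on an aromatic ring. The same change separates compound 2 from compound 1, namely (butyl in place of hydrogen on a saturated chain carbon, four bonds along the chain from a nitrogen on an aromatic ring), and the place is described in the same words for both pairs, so it is the same change made on two cores. The difference between the core of compound 2 and the core of compound 3 is not broken down here. As far as these compounds go, for the measured pair the step is a number no higher from compound 2 to compound 1 (the limit leaves the size open), and its size stays open because of the limit of > 100000 nM in this assay, at which 1 of the 3 values shown sits. Compound 3 sits level with compound 1 at the digits shown. Since the first change left compound 1 at 100000 nM, the expected step from compound 3 to compound 4 in this assay is no change at the digits printed from compound 3 to compound 4 (within the scatter). Compound 4 is therefore estimated at 100000 nM, between 50000 nM and 100000 nM.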

Compound 4, minimum cytotoxic concentration: 4000 nM
Compound 4: the middle estimate sits 25-fold (1.40 log units) above what was measured, and the stated range ends above it.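

In this assay, butyl in place of hydrogen on the chain gives a 25-fold lower number from compound 3 to compound 4 (1.40 log units; beyond the scatter), so on this core the longer chain clearly goes with a lower number, which here stands for higher toxicity in the test. The size of the earlier step on the other core, from compound 2 to compound 1, cannot be read because it rests on a limit of the assay, not a number: the limit of > 100000 nM in this assay, at which 1 of the 4 values shown sits. This means the result shows a clear effect on one core, but not whether the same change does the same on both cores: the same change on two cores in this assay, a number no higher (the limit leaves the size open) from compound 2 to compound 1 and a 25-fold lower number (1.40 log units; beyond the scatter) from compound 3 to compound 4; the limit leaves it open whether they differ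

As far as these compounds go, whether a longer chain would lower the number further on the core of compound 3 stays open, and so does the effect of a chain bearing an amine or a carboxylic acid. With only one pair of chain lengths on each core, the compounds shown give no trend along the chain.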